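A few compounds are considered here, and "the series" means these few. Any claim that something is new, unique, unknown or untested is made for them only; others in the source may bear on it.

Compound 1 `O=[N+]([O-])c1ccc(NC(=S)N/N=C\c2ccnc3ccccc23)cc1`: 82500 nM
Compound 2 `S=C(N/N=C\c1ccnc2ccccc12)Nc1cccc2ccccc12`: 22600 nM

In an ADME assay on RAW264.7 cells (Mus musculus) for cytotoxicity, read by MTT assay, with a stated time of 48 h (a lower number here means that less compound is tolerated, a higher number that more compound is tolerated), compound 1 holds the higher of the two numbers, with compound 2 clearly lower. Compound 3 `Cc1ccc(NC(=S)N/N=C\c2ccnc3ccccc23)cc1` keeps the shared core of compound 1 but carries methyl in place of nitro on an aromatic carbon, para to a large group (methyl in place of nitro on an aromatic carbon). Among the measured compounds shown here, no measured pair shows this swap, so the forecast is loose. For the measured compounds named here, with only two values, compound 1 sits at the top, and compound 2 reads 22600 nM. A small expected drop, near the usual scatter, is therefore the best guess: a 1.8-fold lower number from compound 1 to compound 3 (0.26 log units; within the scatter). Compound 3 is estimated at 45000 nM, within a range of 15000 nM to 120000 nM.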

Compound 3, half-maximal cytotoxic concentration: 50500 nM
Compound 3: the middle estimate sits 1.1-fold (0.05 log units) below what was measured; the measured number falls inside the stated range.
By their numbers in this assay, from the lowest: compound 2; then compounds 3 and 1 (each within the scatter of the next).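

Methyl in place of nitro on this aromatic carbon, para to a large group, gives a 1.6-fold lower number from compound 1 to compound 3 (0.21 log units; within the scatter) in this assay and so the two compounds cannot be told apart in this test. At this position, then, a nitro group with its 2 hydrogen-bond acceptors can give way to a methyl group with none, without a shift beyond the scatter. No available measurement explains why this is so.

On these data alone, whether other groups at this position, such as an amine or a carboxylic acid, would behave the same way stays open. A single swap also cannot show whether this result would hold on a different core.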